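The compounds below may be only part of what the source reports. "The series", "measured", "known", "first", "only" and "open" are said of these compounds alone.

Measured so far in a functional assay on CHO cells for agonist activity at prostaglandin E2 receptor EP3 subtype (Homo sapiens), read by fluorescence and calcium flux; a higher number here means that more compound is needed for the effect, a lower number that less compound is needed:

compound 1, `CS(=O)(=O)NC(=O)CCC/C=C\C[C@@H]1[C@@H](/C=C/[C@@H](O)COc2ccccc2)[C@H](O)C[C@@H]1O`, gives 0.34 nM
compound 2, `O=C(O)CCC/C=C\C[C@H]1C(=O)C[C@@H](O)[C@@H]1/C=C/[C@@H](O)COc1ccccc1`, gives 0.89 nM
compound 3, `O=C(O)CCC1=CC[C@@H]2[C@@H](/C=C/[C@@H](O)COc3ccccc3)[C@H](O)C[C@@H]2OC1`, gives 2700 nM

Compound 3 stands highest of the three numbers in this assay; the nearest value is that of compound 2 and the furthest that of compound 1, and both gaps lie well beyond the scatter of repeat measurements. Compound 4, `O=C(O)CCCC1=CC[C@@H]2[C@@H](/C=C/[C@@H](O)COc3ccccc3)[C@H](O)C[C@@H]2OC1`, differs from compound 3 in one place: carboxymethyl in place of carboxy on a saturated chain carbon, two bonds along the chain from a double-bonded ring carbon. Going by the values given here, no measured pair carries this kind of chain lengthening, so the expectation for compound 4 rests only on where compound 3 sits. A modest step downward is expected, a 3.0-fold lower number from compound 3 to compound 4 (0.48 log units; beyond the scatter), while the number should remain far from those of compound 1 and compound 2. For compound 4 in this assay the estimate is 900 nM, with an expected range from 150 nM to 5000 nM.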

Compound 4, half-maximal effective concentration: 4700 nM
Beside the measured number, compound 4's estimate is 5.2-fold (0.72 log units) below it, within the range that was stated.
By their numbers in this assay, from the lowest: compound 1; then compound 2; then compounds 3 and 4 (each within the scatter of the next).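

Carboxymethyl in place of carboxy on a saturated chain carbon, two bonds along the chain from a double-bonded ring carbon, gives a 1.7-fold higher number from compound 3 to compound 4 (0.24 log units; within the scatter) in this assay. Going by these compounds alone, this is the first measured pair carrying this chain lengthening, and at this position the change does not separate the two compounds in this assay. No available measurement accounts for this result.

The compounds shown leave open how a longer chain ending in carboxy, or a methyl ester or an amide in place of the terminal carboxy group, would read at this position in this assay. They also leave open whether the same lengthening would give a similarly small step on the core of compound 2, whose number lies far from those of this pair.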